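Methoxy added on the aryl ketone ring of pyrazole chalcones

The compounds below may be only part of what the source reports. "The series", "measured", "known", "first", "only" and "open" are said of these compounds alone.

Compound 1 `COc1ccc(-c2cc(/C=C/C(=O)c3ccc(N)cc3)[nH]n2)cc1` gives 3220 nM in a functional assay on RPMI-8226 cells (Homo sapiens) for inhibition, read by sulforhodamine B assay, with a stated time of 48 h; on this read-out lower numbers stand for stronger inhibition of growth and higher numbers for weaker inhibition of growth. Compound 3 `COc1ccc(-c2cc(/C=C/C(=O)c3ccc(N)cc3)[nH]n2)cc1OC` differs from it by one group, (methoxy in place of hydrogen on an aromatic carbon), and in this assay compound 3 gives 5520 nM; the step of a 1.7-fold higher number from compound 1 to compound 3 (0.23 log units; within the scatter) is within the scatter, so the two values are treated as the same.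

Compound 2 `COc1ccc(C(=O)/C=C/c2cc(-c3cc(OC)c(OC)c(OC)c3)n[nH]2)cc1OC` gives 1110 nM in this assay, the lowest of the three numbers, and its gaps to compound 1 and to compound 3 are both beyond the scatter. How the core of compound 2 differs from the core of compound 1 is not broken down here.

Compound 4 `COc1cc(C(=O)/C=C/c2cc(-c3cc(OC)c(OC)c(OC)c3)n[nH]2)cc(OC)c1OC` is not yet measured. It differs from compound 2 by methoxy in place of hydrogen on an aromatic carbon. This is the same kind of change as that from compound 1 to compound 3, but not the same: in compound 4 the place is ortho to a methoxy group, meta to a large group and meta to a methoxy group, whereas in compound 3 it is ortho to a methoxy group and meta to a large group only. For the measured compounds named here, for compound 4 the expected step is a 1.4-fold higher number from compound 2 to compound 4 (0.16 log units; within the scatter), resting on a 1.7-fold higher number from compound 1 to compound 3 (0.23 log units; within the scatter), the only measured instance of this kind of change, which stayed within the scatter. Compound 4 is therefore estimated at 1600 nM in this assay, with a range from 700 nM to 4000 nM; the range is wide since one step from a different core is all that supports it.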

Compound 4, concentration for total growth inhibition: 2060 nM
Estimate against measurement, compound 4: 1.3-fold (0.11 log units) below; the measured number falls inside the stated range.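

In this assay, methoxy in place of hydrogen on an aromatic carbon gives a 1.9-fold higher number from compound 2 to compound 4 (0.27 log units; within the scatter), so this pair, like the earlier one, shows no change that can be told from repeat variation. Set side by side, the two steps show that the change carries from one core to the other without a detectable difference in its size: the same change on two cores in this assay, a 1.7-fold higher number (0.23 log units; within the scatter) from compound 1 to compound 3 and a 1.9-fold higher number (0.27 log units; within the scatter) from compound 2 to compound 4, 1.1-fold (0.03 log units) apart, within the scatter of two such steps

This supports only a narrow reading, that the step stayed within the scatter on the two cores shown; it does not establish a real shift of the same size on both, and two pairs cannot show that the result holds on any further core, or separate the effect of core from that of place, since in compound 4 the new methoxy is also meta to a methoxy group, which is not so in compound 3.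

The compounds shown leave open what a hydroxy group, an ethoxy group or a chlorine atom at the same place would do on either core. Also open, going by these compounds, is whether a step of this kind stays within the scatter when the methoxy enters at a place with a different set of neighbours.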